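Swapping a Hydroxyethyl Chain for Methoxypropyl

The compounds below may be only part of what the source reports. "The series", "measured", "known", "first", "only" and "open" are said of these compounds alone.

In a toxicity assay on EA.hy 926 cells (Homo sapiens) for cytotoxicity, read by MTT assay, with a stated time of 48 h (a lower number here means a stronger inhibitor, a higher number a weaker inhibitor), compound 3 (`O=C(/C=C(/C=C/c1ccc(O)cc1)NCCO)/C=C/c1ccc(O)cc1`) gives 50200 nM and stands within the scatter of both compound 1 (`O=C(/C=C(/C=C/c1ccc(O)cc1)NCCCO)/C=C/c1ccc(O)cc1`) at 57300 nM and compound 2 (`COCCNC(=C\C(=O)/C=C/c1ccc(O)cc1)/C=C/c1ccc(O)cc1`) at 45100 nM in this small set. The change to compound 4 (`COCCCNC(=C\C(=O)/C=C/c1ccc(O)cc1)/C=C/c1ccc(O)cc1`) is methoxymethyl in place of hydroxy on a saturated chain carbon, two bonds along the chain from an amine nitrogen and it turns (2-hydroxyethyl)amino into (3-methoxypropyl)amino. For the measured compounds named here, two measured steps bear on it: a 1.1-fold lower number from compound 1 to compound 3 (0.06 log units; within the scatter) for the chain change and a 1.1-fold higher number from compound 2 to compound 3 (0.05 log units; within the scatter) for hydrogen in place of methyl on an oxygen. Neither leaves the scatter, so no step beyond the scatter is expected in this assay for this change. Compound 4 is therefore estimated at 50000 nM (expected range 32000 nM to 78000 nM).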

Compound 4, half-maximal inhibitory concentration: 81900 nM
Estimate against measurement, compound 4: 1.6-fold (0.21 log units) below; the measured number lies above the stated range.
By their numbers in this assay, from the lowest: compounds 2, 3, 1 and 4 (each within the scatter of the next).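

Across the four chains, this position shows no step beyond the scatter in this assay, and that now includes the (3-methoxypropyl)amino group: a 1.6-fold higher number from compound 3 to compound 4 (0.21 log units; within the scatter), a 1.8-fold higher number from compound 2 to compound 4 (0.26 log units; within the scatter) and a 1.4-fold higher number from compound 1 to compound 4 (0.16 log units; within the scatter). Methyl in place of hydrogen on the oxygen also has a second reading, and the two readings agree within the scatter: the same change on two cores in this assay, a 1.1-fold higher number (0.05 log units; within the scatter) from compound 2 to compound 3 and a 1.4-fold lower number (0.16 log units; within the scatter) from compound 4 to compound 1, 1.6-fold (0.20 log units) apart, within the scatter of two such steps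

All four chains end in hydroxy or methoxy. The compounds shown leave open what an amine, a carboxylic acid or a longer chain would give at this position in this assay.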